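A Selenium Methyl Exchanged for Hydrogen

The source may report more compounds than this note shows. Statements on the series, on what has been measured and on what is new or still open speak of the compounds shown alone.

Compound 1 `COc1ccc(CNc2nc([Se]C)nc3ccccc23)cc1` carries a methyl on its selenium. In a functional assay on CCRF-CEM cells (Homo sapiens) for cytotoxicity, read by MTT assay, with a stated time of 72 h (a lower number here means a stronger inhibitor of growth, a higher number a weaker inhibitor of growth), compound 1 gives > 100000 nM, which is a limit of the assay and not a number. Among the three values shown, compound 1 therefore stands at the limit of > 100000 nM in this assay, at which 2 of the 3 values shown sit. Compound 2 `C[Se]c1nc(N)c2ccccc2n1` is a smaller relative with a free amino group, and in this assay compound 2 gives 65100 nM. Compound 3 `CCCCC[Se]c1nc([Se]CCCCC)c2cccnc2n1` bears two pentyl chains on selenium. In this assay compound 3 gives > 100000 nM, again a limit of the assay rather than a number. Going by the values given here, no two measured compounds differ in a single place, so the three values stand side by side without a measured step among them.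

Compound 4 `COc1ccc(CNc2nc([SeH])nc3ccccc23)cc1` differs from compound 1 by hydrogen in place of methyl on a selenium. Among the compounds with values here, since compound 1 sits at a limit, no measured step can anchor the change, and the change itself is small. The expected step is a number no higher from compound 1 to compound 4 (the limit leaves the size open), which is not beyond the scatter in either direction. For compound 4 the estimate in this assay is 100000 nM, with a range from 30000 nM to 300000 nM. A limit rather than a number is expected to be the more likely outcome for compound 4.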

Compound 4, concentration for 50% growth inhibition: > 100000 nM
Compound 4 ended at the assay's limit; the forecaster's own chance of this, stated with the estimate: 60%; the middle value lies on the limit itself.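

No step can be read between compound 1 and compound 4, as both stand at a limit of the assay and not at a number: the limit of > 100000 nM in this assay, at which 3 of the 4 values shown sit.

The compounds shown leave open whether hydrogen in place of methyl on a selenium changes growth inhibition at all in this assay.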